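The compounds below may be only part of what the source reports. "The series", "measured", "known", "first", "only" and "open" are said of these compounds alone.

Measured so far:
- compound 1 `O=C(O)CCC(=O)OCCCCCCSc1ccc([N+](=O)[O-])c2nonc12` gives 2830 nM
- compound 2 `COc1ccc(NC(=O)CCC(=O)OCCCCCCSc2ccc([N+](=O)[O-])c3nonc23)cc1OC` gives 2770 nM

In a functional assay on 143B cells (Homo sapiens) for inhibition, read by MTT assay, with a stated time of 72 h (a higher number here means a weaker inhibitor, a lower number a stronger inhibitor), compound 2 gives 2770 nM and stands level with compound 1, as the two numbers lie within the usual scatter of each other. The next compound to be tested is compound 3 `O=C(CCC(=O)N1CCOCC1)OCCCCCCSc1ccc([N+](=O)[O-])c2nonc12`. Its structure differs from that of compound 2 at one place, on a carbonyl carbon whose other neighbour is a saturated chain carbon, with morpholin-4-yl in place of (3,4-dimethoxyphenyl)amino on a carbonyl carbon.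

Within the data shown here, only one measured step bears on this change, as it alters the same carbonyl carbon, with (3,4-dimethoxyphenyl)amino in place of hydroxy. That step is a 1.0-fold lower number from compound 1 to compound 2 (0.01 log units; within the scatter). It is small, so it gives no reason to expect a shift in this assay in either direction. Still, a single step is thin evidence, and morpholin-4-yl has not yet been measured at this place. The estimated change is a 1.0-fold higher number from compound 2 to compound 3 (0.00 log units; within the scatter), meaning that no step beyond the scatter is expected. For compound 3 the estimated value is 2800 nM, with an expected range from 1500 nM to 5000 nM.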

Compound 3, half-maximal inhibitory concentration: 1530 nM
For compound 3 the middle estimate is 1.8-fold (0.26 log units) above the measured one, and the stated range covers the measured number.
By their numbers in this assay, from the lowest: compounds 3, 2 and 1 (each within the scatter of the next).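

In this assay morpholin-4-yl in place of (3,4-dimethoxyphenyl)amino gives a 1.8-fold lower number from compound 2 to compound 3 (0.26 log units; within the scatter), and morpholin-4-yl in place of hydroxy gives a 1.8-fold lower number from compound 1 to compound 3 (0.27 log units; within the scatter). Among these compounds, the earlier pair showed only that an aromatic amide group and hydroxy read alike on this carbonyl carbon; these steps add a non-aromatic ring with 6 heavy atoms and 0 hydrogen-bond donors, and all three compounds still lie within the scatter of one another, so across these three groups the number stays level at this place, whether the group is a large aromatic one, a smaller saturated ring or hydroxy. Nothing measured alongside these numbers accounts for how close they lie.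

The compounds shown leave open whether any group on this carbonyl carbon can move the number beyond the scatter, for example a piperazin-1-yl ring, a benzylamino group or a simple methoxy group. All three compounds also share the same chain and core, so the reading in this assay of a longer chain remains an open question.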